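Working notes: from compound 2 to compound 4

A few compounds are considered here, and "the series" means these few. Any claim that something is new, unique, unknown or untested is made for them only; others in the source may bear on it.

Values in a functional assay on HCT-116 cells (Homo sapiens) for inhibition, read by CCK-8 assay, with a stated time of 48 h; on this read-out higher numbers stand for weaker inhibition and lower numbers for stronger inhibition:
compound 1 `COc1cc(-c2ccnc3cc(-c4cccc(C#N)c4)nn23)cc(OC)c1OC`: > 10000 nM (a limit of the assay)
compound 2 `COc1cc(-c2ccnc3cc(-c4ccccc4)nn23)cc(OC)c1OC`: 3880 nM
compound 3 `COc1cc(-c2ccnc3cc(-c4ccc5cnn(C)c5c4)nn23)cc(OC)c1OC`: 2440 nM

Compound 1 gives only a limit, > 10000 nM. Going by the values given here, compound 2, at 3880 nM, sits close to the only other number in the set, with a 1.6-fold lower number from compound 2 to compound 3 (0.20 log units; within the scatter). Compound 4 `COc1cc(-c2ccnc3cc(-c4ccc(-c5cnn(C)c5)cc4)nn23)cc(OC)c1OC` has 1-methyl-1H-pyrazol-4-yl in place of hydrogen on an aromatic carbon of a six-membered aromatic ring of carbon only, para to a large group: 1-methyl-1H-pyrazol-4-yl in place of hydrogen on an aromatic carbon.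

Among the compounds with values here, no measured step adds this group. The closest guide is the replacement of phenyl by 1-methyl-1H-indazol-6-yl, with a 1.6-fold lower number from compound 2 to compound 3 (0.20 log units; within the scatter). The other step that bears on the change, an at least 2.5-fold lower number from compound 1 to compound 2 (0.41 log units; beyond the scatter), shows that a substituent on this ring can matter, so a loss of activity in this assay remains possible. On these data alone, no step beyond the scatter is therefore expected, and the direction stays open. The expected step is a 1.6-fold lower number from compound 2 to compound 4 (0.19 log units; within the scatter). Compound 4 is estimated at 2500 nM, with an expected range of 600 nM to 10000 nM.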

Compound 4, half-maximal inhibitory concentration: 2110 nM
For compound 4 the middle estimate is 1.2-fold (0.07 log units) above the measured one, within the range that was stated.
By their numbers in this assay, from the lowest: compounds 4, 3 and 2 (each within the scatter of the next). At a limit, above all of these: compound 1.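

In this assay, a 1.8-fold lower number from compound 2 to compound 4 (0.26 log units; within the scatter), so the aromatic carbon para to a large group accepts 1-methyl-1H-pyrazol-4-yl, with its 6 heavy atoms, without a step beyond the scatter. This addition therefore shows neither a clear gain nor a clear loss at this position, and the earlier possibility of a loss in this assay does not materialise for this group. Nothing given here accounts for this outcome or bears on the result.

Open, on these data alone, is whether a different kind of group at the same carbon, such as a primary amine, a carboxylic acid or a morpholine, would give a step beyond the scatter. Also open, as far as these compounds go, is whether the methyl on the pyrazole matters, which a 1H-pyrazol-4-yl group at this carbon would test.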